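The compounds below may be only part of what the source reports. "The series", "measured", "known", "first", "only" and "open" are said of these compounds alone.

Compound 1 `COc1ccc(N(C)c2nc(C)nc3ccccc23)cc1`: 2 nM
Compound 2 `COc1cccc2cc(N(C)c3nc(C)nc4ccccc34)ccc12`: 2.5 nM

Both compounds were tested in a functional assay on HeLa cells (Homo sapiens) for cytotoxicity, read by sulforhodamine B assay; a lower number here means a stronger inhibitor, a higher number a weaker inhibitor. There, compound 2 gives 2.5 nM, which lies within the scatter of compound 1 at 2 nM. The two therefore stand level on these numbers.

Compound 3 `COc1cccc2cc(N(C)c3nc(Cl)nc4ccccc34)ccc12` has yet to be measured in this assay. It departs from compound 2 by chloro in place of methyl on an aromatic carbon, with chloro in place of methyl on an aromatic carbon, between two ring nitrogen atoms. Compound 1 and compound 2 both carry the methyl, so the measured pair offers no direct guide to this change. A small move toward a higher number is expected, possibly not much beyond the scatter. The estimated change is a 2.4-fold higher number from compound 2 to compound 3 (0.38 log units; beyond the scatter). The expected value for compound 3 is 6 nM, with an estimated range of 1.5 nM to 25 nM.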

Compound 3, half-maximal inhibitory concentration: 2.8 nM
Estimate against measurement, compound 3: 2.1-fold (0.33 log units) above; the range from low to high includes it.
By their numbers in this assay, from the lowest: compounds 1, 2 and 3 (each within the scatter of the next).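

In this assay the exchange of methyl for chloro on an aromatic carbon, between two ring nitrogen atoms, moves the value by no meaningful amount (a 1.1-fold higher number from compound 2 to compound 3 (0.05 log units; within the scatter)). Among the compounds shown here, this position held methyl in both earlier compounds, so this is the first sign that it accepts another group: methyl is not needed here for a low nanomolar value, at least when chloro replaces it. The data offer no measurement that explains why the two groups stand level.

The compounds shown leave open whether this position would tolerate an amine, a methoxy group or a longer chain, or hydrogen alone. They also leave open whether chloro would give the same result on the core of compound 1.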